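The source may report more compounds than this note shows. Statements on the series, on what has been measured and on what is new or still open speak of the compounds shown alone.

Compound 1, `O=C(Nc1cccc(-n2cc(-c3ccncc3)c(-c3ccc(Cl)c(O)c3)n2)c1)Nc1cccc(C(F)(F)F)c1`: > 32500 nM in a functional assay on ACHN cells (Homo sapiens) for inhibition, read by sulforhodamine B assay, with a stated time of 48 h; a lower number here means a stronger inhibitor of growth, a higher number a weaker inhibitor of growth
Compound 2, `O=C(Nc1cccc(-n2cc(-c3ccncc3)c(-c3ccc(Cl)c(O)c3)n2)c1)Nc1ccc(Cl)c(Cl)c1`: > 32500 nM in this assay
Compound 3, `COc1cc(-c2nn(-c3cccc(NC(=O)Nc4ccc(Cl)c(C(F)(F)F)c4)c3)cc2-c2ccncc2)ccc1Cl`: 15600 nM in this assay

Among the three measured compounds, compound 3 is the only one that gives a number in this assay; compound 3 gives 15600 nM. The value of compound 1 in this assay is a limit of the assay and not a number. The value of compound 2 in this assay is likewise a limit. Going by the values given here, the single measured step, a step that the two limits leave unreadable from compound 1 to compound 2, exchanges 3-(trifluoromethyl)phenyl for 3,4-dichlorophenyl on an amide-type nitrogen, and its size cannot be read, both ends sitting at the same limit.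

Compound 4, `O=C(Nc1cccc(-n2cc(-c3ccncc3)c(-c3ccc(Cl)c(O)c3)n2)c1)Nc1ccc(Cl)c(C(F)(F)F)c1`, differs from compound 3 in one place: hydrogen in place of methyl on an oxygen on an aromatic ring. Among the compounds with values here, no measured step covers this change directly. What the measured compounds do show is that both compounds carrying the hydroxy group sit at the limit of > 32500 nM in this assay, at which 2 of the 3 values shown sit, while the methoxy compound gives a number. That pattern rests on three compounds only. Compound 4 is therefore expected to give about 35000 nM in this assay, with a range from 15000 nM to 80000 nM. The step this estimate means is a 2.2-fold higher number from compound 3 to compound 4 (0.35 log units; beyond the scatter), expected to run toward weaker growth inhibition, quite possibly ending at the limit.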

Compound 4, concentration for total growth inhibition: > 32500 nM
Compound 4 gave a limit, no number (the forecaster's own chance of this, stated with the estimate: 65%); the middle value does not contradict the limit.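

The change of methoxy to hydroxy on the 4-chloro-3-methoxyphenyl group now has a comparison in one place: in this assay, hydrogen in place of methyl on that oxygen gives an at least 2.0-fold higher number from compound 3 to compound 4 (0.31 log units; beyond the scatter). Going by these compounds alone, no earlier pair isolated this change, and here the only compound with a number loses it when nothing else differs, so the step has a lower bound while its full size remains unknown. The steps from compound 1 and from compound 2 to compound 4 cannot be read, because the three hydroxy compounds all stand at the same limit of the assay: the limit of > 32500 nM in this assay, at which 3 of the 4 values shown sit.

On these data alone, how far compound 4 lies past its limit remains open, and so does whether methoxy would also give a number when paired with the 3-(trifluoromethyl)phenyl group of compound 1 or the 3,4-dichlorophenyl group of compound 2. Also open is how an ethoxy group, an amine or a longer chain ending in a carboxylic acid would read at this position, since the compounds shown carry only methoxy or hydroxy there.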